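Compound 3 to compound 4: exchanging the pyrazolyl group

A few compounds are considered here, and "the series" means these few. Any claim that something is new, unique, unknown or untested is made for them only; others in the source may bear on it.

- compound 1 `Cn1nccc1-c1cnc(NCc2c(F)ccc3c2CCO3)c2cn[nH]c(=O)c12`: 2.6
- compound 2 `Cc1nc(CO)ccc1-c1cnc(NCc2c(F)ccc3c2CCO3)c2cn[nH]c(=O)c12`: 2.4
- compound 3 `CN(C)C(=O)c1cc(-c2cnc(NCc3c(F)ccc4c3CCO4)c3cn[nH]c(=O)c23)n(C)n1`: 2.1

In a physicochemical assay for lipophilicity, using the shake flask method, in phosphate buffer, measured as octanol-water partition, with a stated time of 30 min, at pH 7.4 (on this read-out higher numbers stand for higher lipophilicity and lower numbers for lower lipophilicity), compound 3 gives 2.1. The other two compounds relate to it through a number 0.50 log units lower from compound 1 to compound 3 (beyond the scatter) and a number 0.30 log units lower from compound 2 to compound 3 (within the scatter).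

The next step leads to compound 4 `Cc1ncccc1-c1cnc(NCc2c(F)ccc3c2CCO3)c2cn[nH]c(=O)c12`, with 2-methylpyridin-3-yl in place of 3-(dimethylcarbamoyl)-1-methyl-1H-pyrazol-5-yl on an aromatic carbon.

Within the data shown here, three measured steps bear on this. Compound 1 lacks only the dimethylcarbamoyl, and read backwards, a number 0.50 log units lower from compound 1 to compound 3 (beyond the scatter) points upward. Exchanging the ring substituent alone gave a number 0.20 log units lower from compound 1 to compound 2 (within the scatter), so that exchange offers little guidance. Compound 2 carries the entering group plus a hydroxymethyl, and a number 0.30 log units lower from compound 2 to compound 3 (within the scatter) also points upward when read backwards. Among the measured compounds shown here, no measured step isolates that hydroxymethyl, which compound 4 lacks.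

A rise beyond the scatter is therefore expected, estimated as a number 0.70 log units higher from compound 3 to compound 4 (beyond the scatter). For compound 4 the estimated value is 2.8, with an expected range from 2.4 to 3.2.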

Compound 4, distribution coefficient: 3
Estimate against measurement, compound 4: 0.20 log units below, within the range that was stated.
By their numbers in this assay, from the lowest: compounds 3, 2 and 1 (each within the scatter of the next, the first and the last beyond it); then compound 4.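

In this assay, among these compounds, the hydroxymethyl can now be read on its own: taking it away gave a number 0.60 log units higher from compound 2 to compound 4 (beyond the scatter), a step that no earlier pair isolated. The ring exchange also becomes visible once that group is absent, with 2-methylpyridin-3-yl in place of 1-methyl-1H-pyrazol-5-yl giving a number 0.40 log units higher from compound 1 to compound 4 (beyond the scatter), and the full exchange from the substituted pyrazolyl group gives the largest step among these compounds, a number 0.90 log units higher from compound 3 to compound 4 (beyond the scatter). Nothing available explains why these groups shift the number as they do.

The compounds shown leave open how an amine or a carboxylic acid in place of the hydroxymethyl would read in this assay. They also leave open what a longer chain in place of the methyl on the 2-methylpyridin-3-yl group would do.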